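Removing One Benzyloxy Group from a Weak Inhibitor

The source may report more compounds than this note shows. Statements on the series, on what has been measured and on what is new or still open speak of the compounds shown alone.

Of the compounds shown here, two have been measured in a functional assay, read by spectrophotometry, with a stated time of 1 h; a higher number here means a weaker inhibitor, a lower number a stronger inhibitor. Compound 1 `O=c1cc(/C=N\c2ccc(O)cc2)c2ccc(OCc3ccccc3)cc2o1` gives 233000 nM in this assay, while compound 2 `Nc1ccccc1/N=C\c1cc(=O)oc2cc(OCc3ccccc3)cc(OCc3ccccc3)c12` gives 624000 nM, the higher of the two numbers, so compound 2 is the weaker inhibitor of the pair. Compound 3 `Nc1ccccc1/N=C\c1cc(=O)oc2cc(OCc3ccccc3)ccc12` is made from compound 2 by one change, (hydrogen in place of benzyloxy on an aromatic carbon). Going by the values given here, no pair of measured compounds differs by this change alone, so the step from compound 2 to compound 3 in this assay is expected to be small, a 1.4-fold lower number from compound 2 to compound 3 (0.14 log units; within the scatter), and not clearly beyond the scatter in either direction. In this assay compound 3 is expected to give about 450000 nM, within a range from 150000 nM to 1200000 nM.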

Compound 3, half-maximal inhibitory concentration: 34600 nM
Estimate against measurement, compound 3: 13-fold (1.11 log units) above; measured number below the stated range.
By their numbers in this assay, from the lowest: compound 3; then compound 1; then compound 2.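

In this assay, replacing benzyloxy with hydrogen on the aromatic carbon ortho to a fused ring gives an 18-fold lower number from compound 2 to compound 3 (1.26 log units; beyond the scatter) with the rest of the molecule unchanged, so this position clearly affects inhibition. Going by these compounds alone, with only one benzyloxy group on the core, placing 2-aminophenyl instead of 4-hydroxyphenyl on the double-bonded nitrogen gives a 6.7-fold lower number from compound 1 to compound 3 (0.83 log units; beyond the scatter) as well, so that site also counts. Nothing measured here explains either step.

As far as these compounds go, whether a methoxy group or a fluorine atom on this carbon would behave more like hydrogen or like benzyloxy remains open. So does whether removing benzyloxy would give a similar step with 4-hydroxyphenyl on the nitrogen.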